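Cytotoxicity notes on a small 1,2,4-dioxazoline-free series

This account rests on a few compounds, and the source may have more. Where it says the series, first, only, none or still open, it means among the compounds named here.

Two cores appear here. Compound 1 `O=[N+]([O-])c1ccc(C2=NOC(c3ccccc3)O2)s1` and compound 2 `CC1(c2ccccc2)ON=C(c2ccc([N+](=O)[O-])s2)O1` share one core; compound 3 `Cc1ccc(C2=NOC(c3ccccc3)O2)cc1` and the unmeasured compound 4 `Cc1ccc(C2=NOC(C)(c3ccccc3)O2)cc1` share another, and the difference between the two cores is not broken down here. In an ADME assay on Vero cells (Chlorocebus sabaeus) for cytotoxicity, read by sulforhodamine B assay, with a stated time of 72 h (a higher number here means a weaker inhibitor, a lower number a stronger inhibitor), compound 1 gives only a limit, < 180000 nM. Compound 2 likewise returns a limit in this assay, < 180000 nM. The change methyl in place of hydrogen on a saturated ring carbon therefore yields a step that the two limits leave unreadable from compound 1 to compound 2, since the limit of < 180000 nM in this assay, at which 2 of the 3 values shown sit, holds for both ends. In this assay compound 3 gives "not determined" (no result reported). The change methyl in place of hydrogen on a saturated ring carbon is the same kind of change, the place differing only in that the ring atom bears a group of 7 heavy atoms rather than 8. No step size can be carried over, so compound 4 is expected in this assay to give about 150000 nM, likely again as a limit, in the range 30000 nM to 200000 nM.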

Compound 4, half-maximal inhibitory concentration: > 180000 nM
Compound 4 ended at the assay's limit; the forecaster's own chance of this, stated with the estimate: 70%; middle value at least 1.2-fold (0.07 log units) away from the limit.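

In this assay, among the compounds shown here, compound 3 gives "not determined" (no result reported) and no new step to compound 4 can be read. Compound 4 gives > 180000 nM as a limit of the assay. The compounds shown leave open how large the change from hydrogen to methyl is on either core.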